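Pyrazoline sulfonamides: hydroxyphenyl to trimethoxyphenyl on the saturated carbon

This account rests on a few compounds, and the source may have more. Where it says the series, first, only, none or still open, it means among the compounds named here.

Measured so far:
compound 1 `Cc1cc(O)c(C2=NN(c3ccc(S(N)(=O)=O)cc3)C(c3ccccc3O)C2)cc1Cl` — 8090 nM
compound 2 `Cc1cc(O)c(C2=NN(c3ccc(S(N)(=O)=O)cc3)C(c3ccccc3Cl)C2)cc1Cl` — 6340 nM

In a functional assay on SF-295 cells (Homo sapiens) for antiproliferative activity, with a stated time of 48 h (a higher number here means that more compound is tolerated, a lower number that less compound is tolerated), compound 1 gives 8090 nM, the highest of the measured numbers; its nearest neighbour is compound 2, and the change a 1.3-fold lower number from compound 1 to compound 2 (0.11 log units; within the scatter) sits within the scatter, so the pair shows no real difference.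

Compound 3 `COc1ccc(C2CC(c3cc(Cl)c(C)cc3O)=NN2c2ccc(S(N)(=O)=O)cc2)c(OC)c1OC` has not yet been measured. Against compound 1 the difference is 2,3,4-trimethoxyphenyl in place of 2-hydroxyphenyl on a saturated ring carbon of the shared core. Going by the values given here, the only measured step at this position, a 1.3-fold lower number from compound 1 to compound 2 (0.11 log units; within the scatter), swapped hydroxy for chloro on the aromatic carbon and stayed within the scatter; it shows that the aryl group on this carbon can be altered without a large shift, but says nothing specific about three methoxy groups. Among the compounds with values here, no other step bears on the change.

The expectation for compound 3 in this assay is therefore a step of a 1.2-fold lower number from compound 1 to compound 3 (0.06 log units; within the scatter), not beyond the scatter, with a wide range given the lack of direct precedent. The estimated value for compound 3 is 7000 nM, between 2500 nM and 20000 nM.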

Compound 3, concentration lethal to 50% of the cells: 8700 nM
Compound 3: middle estimate off by 1.2-fold (0.09 log units), on the low side; measured number inside the range.
By their numbers in this assay, from the lowest: compounds 2, 1 and 3 (each within the scatter of the next).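

In this assay, the far larger exchange on the saturated ring carbon, 2,3,4-trimethoxyphenyl in place of 2-hydroxyphenyl, gives a 1.1-fold higher number from compound 1 to compound 3 (0.03 log units; within the scatter) and so stays as flat as the earlier single-substituent swap did. The entering group has 12 heavy atoms, 0 hydrogen-bond donors and 3 hydrogen-bond acceptors against 7, 1 and 1 for the group it replaces, so among these compounds neither the added bulk of three methoxy groups nor the loss of the hydroxy donor shifts the number beyond the scatter, and the comparison with the chloro analogue, a 1.4-fold higher number from compound 2 to compound 3 (0.14 log units; within the scatter) for 2,3,4-trimethoxyphenyl in place of 2-chlorophenyl, agrees with this, leaving all three aryl groups at this carbon indistinguishable. No measurement in hand accounts for this insensitivity.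

Going by these compounds, all three compounds carry a neutral substituted phenyl group at this carbon, so it remains open whether an aminomethyl or carboxylic acid substituent on that phenyl, or a cyclohexyl ring or longer alkyl chain in its place, would move the number beyond the scatter. On these data alone, the 5-chloro-2-hydroxy-4-methylphenyl and 4-sulfamoylphenyl groups are common to all three, so what they contribute also remains open.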